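This account rests on a few compounds, and the source may have more. Where it says the series, first, only, none or still open, it means among the compounds named here.

In a functional assay on SW-620 cells (Homo sapiens) for cytotoxicity, read by MTT assay, with a stated time of 72 h (on this read-out lower numbers stand for stronger inhibition and higher numbers for weaker inhibition), compound 2 `Cc1ccc(/C=C2\S/C(=N\c3csc(-c4ccc(Cl)cc4)c3)NC2=O)cc1` gives 1500 nM, while compound 1 `COc1ccc(/C=C2\S/C(=N\c3csc(-c4ccc(Cl)cc4)c3)NC2=O)cc1` gives 28100 nM. Within the data shown here, the single change between them, (methoxy in place of methyl on an aromatic carbon), produced a 19-fold higher number from compound 2 to compound 1 (1.27 log units; beyond the scatter). Compound 3 `COc1cccc(N2C(=O)CS/C2=N\c2csc(-c3ccc(C)cc3)c2)c1` rests on a different core, and the difference between the two cores is not broken down here. In this assay compound 3 gives only a limit, > 50000 nM, which is the limit of > 50000 nM in this assay, at which 1 of the 3 values shown sits. Compound 4 `COc1ccc(-c2cc(/N=C3\SCC(=O)N3c3cccc(OC)c3)cs2)cc1` carries the same change as before, (methoxy in place of methyl on an aromatic carbon). Because the earlier step was a 19-fold higher number from compound 2 to compound 1 (1.27 log units; beyond the scatter), the change is expected to weaken compound 4 as well, and the expected step from compound 3 to compound 4 is a step that the limit leaves unreadable from compound 3 to compound 4, starting from a value that is already a limit. Compound 4 is therefore expected to give 100000 nM, most likely reported again only as a limit, within a range from 50000 nM to 300000 nM.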

Compound 4, half-maximal inhibitory concentration: 3500 nM
Beside the measured number, compound 4's estimate is 29-fold (1.46 log units) above it; the measured number lies below the stated range.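

In this assay, replacing 4-methylphenyl with 4-methoxyphenyl gives an at least 14-fold lower number from compound 3 to compound 4 (1.15 log units; beyond the scatter), so the same change that weakened compound 1 relative to compound 2 does not act the same way on this second core: the same change on two cores in this assay, a 19-fold higher number (1.27 log units; beyond the scatter) from compound 2 to compound 1 and an at least 14-fold lower number (1.15 log units; beyond the scatter) from compound 3 to compound 4, at least 260-fold (2.42 log units) apart, beyond the scatter of two such steps

Compound 3 gives > 50000 nM, which is a limit and not a number, so the new step marks only a minimum size: the limit of > 50000 nM in this assay, at which 1 of the 4 values shown sits.

With one pair on each core, the result shows that this change cannot be carried safely from one core to the other, but not which feature of the cores reverses its direction.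

Going by these compounds, it remains open how an amine or a longer chain such as ethoxy in the same place would behave on either core.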